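Des-chloro acylhydrazone analogue: expected growth-inhibition read-out

A few compounds are considered here, and "the series" means these few. Any claim that something is new, unique, unknown or untested is made for them only; others in the source may bear on it.

The pair of measured compounds shares a dimethoxystyryl fragment but differs in the linker. Compound 1 `COc1ccc(OC)c(/C=C/c2nnc(Nc3ccc(Cl)cc3)o2)c1` gives 21000 nM in a functional assay on OVCAR-8 cells (Homo sapiens) for antiproliferative activity, read by sulforhodamine B assay, with a stated time of 48 h; on this read-out higher numbers stand for weaker inhibition of growth and lower numbers for stronger inhibition of growth. Compound 2 `COc1ccc(OC)c(/C=C/C(=O)N/N=C/c2ccc(Cl)cc2)c1` is the open acylhydrazone with a 4-chlorophenyl end. In this assay compound 2 reaches only the limit of the assay, > 100000 nM, so no number is known for it. Compound 2 sits at the limit of > 100000 nM in this assay, at which 1 of the 2 values shown sits. Among the numbers shown, compound 2 therefore stands at the weak end, defined by a limit rather than a value.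

Compound 3 `COc1ccc(OC)c(/C=C/C(=O)N/N=C/c2ccccc2)c1` differs from compound 2 by hydrogen in place of chloro on an aromatic carbon, para to a large group, or, cut one bond further out, 4-chlorophenyl to phenyl. Among the measured compounds shown here, no measured pair changes one place only, so no step size can be read from the data. The step from compound 2 to compound 3 is expected to be a number no higher from compound 2 to compound 3 (the limit leaves the size open), nothing beyond the scatter. Compound 3 is accordingly expected to give about 100000 nM in this assay, within 40000 nM to 300000 nM, and most likely to be reported again only as a limit.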

Compound 3, concentration for total growth inhibition: 94600 nM
For compound 3 the middle estimate is 1.1-fold (0.02 log units) above the measured one; low and high end bracket the measured number.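

With hydrogen in place of chloro on an aromatic carbon, para to a large group, the open acylhydrazone gains a measured number: in this assay compound 3 gives 94600 nM. The step is an at least 1.0-fold lower number from compound 2 to compound 3 (0.02 log units; that floor lies within the scatter), so this position is compatible with no real effect of the chloro on the read-out, while a larger step is not excluded. The value of compound 2 remains a limit and not a number, so the true size of the step stays open: the limit of > 100000 nM in this assay, at which 1 of the 3 values shown sits.

Going by these compounds, whether an amine, a methoxy group or a carboxylic acid at this position on the phenyl ring would shift the number in this assay remains open, as the chloro and hydrogen pair alone gives no trend for the position. Compound 1 differs from compound 2 and compound 3 in more than one place, so no step links it to either of them and the contribution of the linker to the read-out cannot be read from the compounds shown.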